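Swapping an amino-alcohol ether for a fluoropyridine

The source may hold more compounds than are shown below. What is called first, only, known or untested is meant among the compounds shown, and "the series" means these compounds.

Three compounds share one core, differing only in the group carried on the outer six-membered aromatic ring. Compound 1 `COc1cc(OC)c2c(=O)cc(-c3ccc(OC4CCN(C)CC4)cc3)oc2c1` bears a methylated piperidinyloxy group; in a functional assay (Homo sapiens) for antiproliferative activity, read by resazurin assay, with a stated time of 48 h, tested at 20 uM (on this read-out lower numbers stand for a weaker effect and higher numbers for a stronger effect at the one concentration tested), compound 1 is recorded as "not determined" (no result reported), so no number exists for it. Compound 2 `COc1cc(OC)c2c(=O)cc(-c3ccc(OCC(O)CN(C)C)cc3)oc2c1` carries a 3-(dimethylamino)-2-hydroxypropoxy chain, and in this assay compound 2 gives 71%. Among the measured compounds shown here, that is the only number in the set, so compound 2 stands alone, with nothing to rank it against.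

Compound 3 `COc1cc(OC)c2c(=O)cc(-c3ccc(-c4ccc(F)nc4)cc3)oc2c1` is not yet measured. It differs from compound 2 as follows: 6-fluoropyridin-3-yl in place of 3-(dimethylamino)-2-hydroxypropoxy on an aromatic carbon. The group that leaves has no ring and one hydrogen-bond donor; the group that enters is one six-membered aromatic ring with one hetero atom and no donor, placed on an aromatic carbon of a ring of carbon only, para to a large group.

For the measured compounds named here, with no measured step to lean on, the author expects a moderate loss, a step from compound 2 to compound 3 of about a number 16 percentage points lower from compound 2 to compound 3 (beyond the scatter), somewhat beyond the usual scatter. Compound 3 is therefore estimated at 55%, in a range from 25% to 85%.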

Compound 3, a percentage reported as inhibition, at one concentration (the size of the read-out at that concentration, not a potency): 19%
Compound 3: the middle estimate sits 36 percentage points above what was measured; measured number below the stated range.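

In this assay, putting 6-fluoropyridin-3-yl in place of 3-(dimethylamino)-2-hydroxypropoxy on this aromatic carbon, para to a large group, comes with a number 52 percentage points lower from compound 2 to compound 3 (beyond the scatter). Among the compounds shown here, this is the first measured step at this position, and it shows that the read-out at the one concentration tested depends strongly on the group carried here, not on the shared core alone. Nothing measured here bears on what lies behind the step.

The change replaces an open chain having one hydrogen-bond donor with an aromatic ring having none, so these compounds cannot separate the loss of the chain, its hydroxyl or its dimethylamino group from the arrival of the ring, the ring nitrogen or the fluorine. A 3-(dimethylamino)propoxy chain without the hydroxyl would address the first part of that question, while an unsubstituted pyridin-3-yl or a plain phenyl ring would address the second, and the compounds shown say nothing about how either would behave.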